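From a Benzyl Ester to an Acyl Urea

This account rests on a few compounds, and the source may have more. Where it says the series, first, only, none or still open, it means among the compounds named here.

Compound 1 `O=C(OCc1ccccc1)C1(S(=O)(=O)c2ccc(Oc3ccc(OC(F)(F)F)cc3)cc2)CCC2(CCNCC2)C1`: in a functional assay on blood (Homo sapiens), with a stated time of 60 min, in the presence of a further agent that is not named here (a higher number here means that more compound is needed for the effect, a lower number that less compound is needed), compound 1 gives > 15000 nM, which is a limit of the assay and not a number.
Compound 2 `O=S(=O)(c1ccc(Oc2ccc(OC(F)(F)F)cc2)cc1)C1(CO)CCC2(CCNCC2)C1`: compound 2 gives > 15000 nM, again a limit.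
Compound 3 `O=C1CN(C(=O)C2(S(=O)(=O)c3ccc(Oc4ccc(OC(F)(F)F)cc4)cc3)CCC3(CCNCC3)C2)CCN1`: compound 3 gives 7500 nM.

Compound 1 therefore stands at the top of what this assay reports, a position it shares with compound 2 (the limit of > 15000 nM in this assay, at which 2 of the 3 values shown sit). Compound 4 `CNC(=O)NC(=O)C1(S(=O)(=O)c2ccc(Oc3ccc(OC(F)(F)F)cc3)cc2)CCC2(CCNCC2)C1` differs from compound 1 by (methylcarbamoyl)amino in place of benzyloxy on a carbonyl carbon. Among the compounds with values here, the only measured step that replaces the benzyloxy group on the same carbonyl carbon is an at least 2.0-fold lower number from compound 1 to compound 3 (0.30 log units; that floor lies within the scatter), a floor that lies within the scatter. A similar small move lower is expected here, giving an at least 1.8-fold lower number from compound 1 to compound 4 (0.27 log units; that floor lies within the scatter). Compound 4 is estimated at 8000 nM, between 3000 nM and 20000 nM.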

Compound 4, half-maximal effective concentration: < 400 nM
Compound 4 was reported as a limit; the forecaster's own chance of this, stated with the estimate: 40%; middle value at least 20-fold (1.30 log units) from the limit.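

On the carbonyl carbon, the group that replaces benzyloxy can shift this assay well beyond the scatter, which compound 3 did not show: (methylcarbamoyl)amino gives an at least 37-fold lower number from compound 1 to compound 4 (1.57 log units; beyond the scatter). The same group gives an at least 18-fold lower number from compound 3 to compound 4 (1.27 log units; beyond the scatter), and the change on the saturated ring carbon gives an at least 37-fold lower number from compound 2 to compound 4 (1.57 log units; beyond the scatter). Compound 4 gives < 400 nM, which is a limit and not a number.

Going by these compounds, how much of the (methylcarbamoyl)amino group this step requires remains open. A plain amino group on the same carbonyl carbon, or an ethyl chain in place of the methyl, would help to test that.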